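This account rests on a few compounds, and the source may have more. Where it says the series, first, only, none or still open, it means among the compounds named here.

Compound 1 `C=C(Br)C(=O)Nc1cccc(/C=C2\SC(=O)N(Cc3ccc(Cl)cc3)C2=O)c1` gives 940 nM in a functional assay on L1210 cells (Mus musculus) for cytotoxicity, read by cell counting, with a stated time of 2 days; on this read-out higher numbers stand for weaker inhibition and lower numbers for stronger inhibition.
Compound 2 `CC(C)(C)c1ccc(CN2C(=O)S/C(=C\c3ccc(N)cc3)C2=O)cc1` gives 94000 nM.
Compound 3 `CC(C)(C)c1ccc(CN2C(=O)S/C(=C\c3cccc(N)c3)C2=O)cc1` gives 223000 nM.

In this assay compound 2 stands second highest of these three numbers. Its nearest neighbour is compound 3, reached by a 2.4-fold higher number from compound 2 to compound 3 (0.38 log units; beyond the scatter); compound 1 is far lower, yet it differs from compound 2 in two places at once, so its number cannot be tied to any single change. Compound 4 `Nc1ccc(/C=C2\SC(=O)N(Cc3ccccc3)C2=O)cc1` differs from compound 2 by hydrogen in place of tert-butyl on an aromatic carbon. Among the measured compounds shown here, no measured step removes a tert-butyl, and the one measured step concerns a different part of the molecule. The step of a 1.6-fold higher number from compound 2 to compound 4 (0.20 log units; within the scatter) is therefore expected to be small and is set slightly toward a higher number. Compound 4 is estimated at 150000 nM, between 40000 nM and 500000 nM.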

Compound 4, half-maximal inhibitory concentration: 38000 nM
The estimate for compound 4 lay 3.9-fold (0.60 log units) above the measured number; measured number outside the range, below it.
By their numbers in this assay, from the lowest: compound 1; then compound 4; then compound 2; then compound 3.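

Taking the tert-butyl away does not weaken the compound: hydrogen in its place gives a 2.5-fold lower number from compound 2 to compound 4 (0.39 log units; beyond the scatter), a modest move toward stronger inhibition. Among the compounds shown here, this is the first measured change at this end of the molecule, as the earlier step only swapped 4-aminophenyl for 3-aminophenyl. No evidence is at hand to explain the shift.

On these data alone, whether a methyl or a methoxy on this aromatic carbon would give a lower or a higher number stays open. Also open, as far as these compounds go, is whether the same change would hold with 3-aminophenyl in the molecule.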